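Carbamoyl to benzoyl: the next step in the series

The source may report more compounds than this note shows. Statements on the series, on what has been measured and on what is new or still open speak of the compounds shown alone.

Three compounds of the shared core have been run in an ADME assay on Jurkat cells (Homo sapiens) for inhibition, read by WST assay, with a stated time of 48 h, tested at 10 uM; a lower number here means less inhibition, a higher number more inhibition at the concentration tested (going by the name of the read-out). Compound 1 `N#Cc1c(-c2ccccc2)nc(Nc2ccc(Cl)cc2)nc1N1CCCCC1` gives 9%. Compound 2 `N#Cc1c(NC2CCCCC2)nc(SCc2ccccc2)nc1-c1ccc(Cl)cc1` gives 0%. Compound 3 `N#Cc1c(-c2ccc(Cl)cc2)nc(SCc2ccccc2)nc1N1CCC(C(N)=O)CC1` gives 19%, the highest of the three numbers; its gap to compound 1 lies within the scatter, its gap to compound 2 beyond it. Among the measured compounds shown here, the one step recorded between neighbours, a number 19 percentage points higher from compound 2 to compound 3 (beyond the scatter), concerns 4-carbamoylpiperidin-1-yl in place of cyclohexylamino on an aromatic carbon, and so does not touch the carbonyl carbon.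

Compound 4 `N#Cc1c(-c2ccc(Cl)cc2)nc(SCc2ccccc2)nc1N1CCC(C(=O)c2ccccc2)CC1` differs from compound 3 by phenyl in place of amino on a carbonyl carbon; cut one bond further out, this reads carbamoyl to benzoyl. For the measured compounds named here, no measured step alters this carbonyl carbon, so the numbers fix no direction for it. The step expected in this assay is therefore a number 1 percentage points higher from compound 3 to compound 4 (within the scatter), nothing beyond the scatter. Compound 4 is estimated at 20%, with a range from 5% to 40%.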

Compound 4, a percentage reported as inhibition, at one concentration (the size of the read-out at that concentration, not a potency): 6%
Estimate against measurement, compound 4: 14 percentage points above; the measured number falls inside the stated range.
By their numbers in this assay, from the lowest: compounds 2, 4, 1 and 3 (each within the scatter of the next, the first and the last beyond it).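

In this assay, among the compounds shown here, phenyl in place of amino on a carbonyl carbon gives a number 13 percentage points lower from compound 3 to compound 4 (beyond the scatter), the first measured change at this carbonyl carbon. What sits there therefore affects the number, and carbamoyl reads higher than benzoyl in this one pair. The change removes a hydrogen-bond donor and adds an aromatic ring of carbon only, and no measurement at hand bears on the cause of the step.

Still open, on these data alone, is whether the step follows from removing amino or from adding phenyl: methylamino or dimethylamino on the same carbonyl carbon, or the corresponding carboxylic acid, would help separate the two. Also open, as far as these compounds go, is whether the step holds elsewhere on the shared core; it rests on a single pair.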